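The source may report more compounds than this note shows. Statements on the series, on what has been measured and on what is new or still open speak of the compounds shown alone.

In a functional assay on KB cells (Homo sapiens) for antiproliferative activity, read by colorimetric assay and MTT assay (on this read-out lower numbers stand for stronger inhibition and higher numbers for weaker inhibition), compound 1 (`COc1ccc(S(=O)(=O)Nc2cccc3cc[nH]c23)cc1`) gives 0.67 ug/mL, compound 2 (`COc1ccc(S(=O)(=O)Nc2ccc(Cl)c3cc[nH]c23)cc1`) gives 0.92 ug/mL and compound 3 (`O=S(=O)(Nc1cccc2cc(O)[nH]c12)c1ccc(Cl)cc1`) gives 1.1 ug/mL, so compound 2 stands within the scatter of both others. Compound 4 (`O=[N+]([O-])c1ccc(S(=O)(=O)Nc2ccc(Cl)c3cc[nH]c23)cc1`) differs from compound 2 by nitro in place of methoxy on an aromatic carbon, para to a large group. Going by the values given here, the only measured step, a 1.4-fold higher number from compound 1 to compound 2 (0.14 log units; within the scatter), comes with chloro in place of hydrogen and lies within the scatter. Among the compounds with values here, it is a different change, and no measured pair tests this one, so no step beyond the scatter is expected in this assay. The estimated step is a 1.0-fold lower number from compound 2 to compound 4 (0.01 log units; within the scatter). For compound 4 the expected value is 0.9 ug/mL, with an estimated range of 0.25 ug/mL to 3 ug/mL.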

Compound 4, half-maximal inhibitory concentration: 9.1 ug/mL
Compound 4: the middle estimate sits 10-fold (1.00 log units) below what was measured; the whole stated range lies below it.
By their numbers in this assay, from the lowest: compounds 1, 2 and 3 (each within the scatter of the next); then compound 4.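

In this assay, going by these compounds alone, nitro in place of methoxy on an aromatic carbon, para to a large group, gives a 9.9-fold higher number from compound 2 to compound 4 (1.00 log units; beyond the scatter) and so is the first step here to pass the scatter. Within the data shown here, this shows that the number responds to the group at this position, whereas the only earlier step, a 1.4-fold higher number from compound 1 to compound 2 (0.14 log units; within the scatter), came from a chloro at another place on the core. Nothing at hand accounts for this step.

The compounds shown leave open whether an amine or a carboxylic acid at this position would give a number nearer that of compound 2 or that of compound 4. They also leave open whether nitro in place of methoxy gives a similar step on the core of compound 1, which has hydrogen where compound 2 has chloro.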